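Methoxy for Methyl on the Second Aryl Ring

The source may hold more compounds than are shown below. What is called first, only, known or untested is meant among the compounds shown, and "the series" means these compounds.

The series shares one core. Compound 1 `CCC(=O)N1N=C(c2ccccc2)CC1c1ccc(F)cc1` in an assay on isolated protein for inhibition of Amine oxidase [flavin-containing] B (Bos taurus) (a higher number here means a weaker inhibitor, a lower number a stronger inhibitor), gives 1150 nM. Compound 2 `CCC(=O)N1N=C(c2ccc(C)cc2)CC1c1ccc(C)cc1` gives 100000 nM, and compound 3 `CCC(=O)N1N=C(c2ccc(C)cc2)CC1c1ccc(OC)cc1` gives 100000 nM. Compound 3 thus stands level with compound 2 at the digits shown, the two together giving the highest numbers of the three, while compound 1, the furthest away, gives a lower number beyond the scatter. Among the compounds with values here, the only single-point step measured so far is no change at the digits printed from compound 2 to compound 3 (within the scatter).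

Compound 4 `CCC(=O)N1N=C(c2ccc(OC)cc2)CC1c1ccc(OC)cc1` carries the same kind of exchange again, now on the other aromatic ring: methoxy in place of methyl on an aromatic carbon. Within the data shown here, the one step that bears on it is the exchange from compound 2 to compound 3, which left the number where it was. On that basis compound 4 is expected to show no step beyond the scatter, no change at the digits printed from compound 3 to compound 4 (within the scatter). Compound 4 is therefore estimated at 100000 nM, with a range from 30000 nM to 100000 nM.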

Compound 4, half-maximal inhibitory concentration: 2400 nM
Beside the measured number, compound 4's estimate is 42-fold (1.62 log units) above it; measured number below the stated range.
By their numbers in this assay, from the lowest: compound 1; then compound 4; then compounds 2 and 3 (each within the scatter of the next).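

In this assay the change from 4-methylphenyl to 4-methoxyphenyl gives a 42-fold lower number from compound 3 to compound 4 (1.62 log units; beyond the scatter) on this aromatic ring, whereas the same kind of exchange on the other aromatic ring gave no change at the digits printed from compound 2 to compound 3 (within the scatter) in the step measured earlier. Across these two steps, then, the result of placing methoxy in place of methyl depends on which ring carries it: the position changed here responds strongly, and the one changed earlier shows no response at the digits printed. Nothing available explains this difference between the two positions.

Going by these compounds, it remains open whether the lower number at this position depends on the methoxy group already present on the other ring. On these data alone, it is also open how this position would respond to an amine, a carboxylic acid or a longer chain such as ethoxy.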